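Swapping Iodine for Chlorine on the Aryl Ring

The compounds below may be only part of what the source reports. "The series", "measured", "known", "first", "only" and "open" are said of these compounds alone.

Of the compounds shown here, three sharing one core have been measured in an assay on HEK-293T cells for displacement of a labelled ligand from corticotropin-releasing factor receptor 1 (Homo sapiens), read by scintillation counting, with a stated time of 2 h; a higher number here means a weaker inhibitor, a lower number a stronger inhibitor. Compound 1 `CCCCN(CC)c1cc(C)nc2c1NC(=O)CN2c1ccc(Cl)cc1Br` gives 2.5 nM, compound 2 `CCCCN(CC)c1cc(C)nc2c1NC(=O)CN2c1ccc(OC)cc1C` gives 4 nM, and compound 3 `CCCCN(CC)c1cc(C)nc2c1NC(=O)CN2c1ccc(I)cc1C` gives 3.4 nM. Compound 3 stands second highest of the three, yet the three numbers sit within the usual scatter of one another, as the steps of a 1.6-fold higher number from compound 1 to compound 2 (0.20 log units; within the scatter), a 1.4-fold higher number from compound 1 to compound 3 (0.13 log units; within the scatter) and a 1.2-fold lower number from compound 2 to compound 3 (0.07 log units; within the scatter) show. Compound 4 `CCCCN(CC)c1cc(C)nc2c1NC(=O)CN2c1ccc(Cl)cc1C` differs from compound 3 by chloro in place of iodo on an aromatic carbon. Going by the values given here, the steps that bear on this change are a 1.2-fold lower number from compound 2 to compound 3 (0.07 log units; within the scatter) and a 1.4-fold higher number from compound 1 to compound 3 (0.13 log units; within the scatter), both within the scatter, so no step beyond the scatter is expected here. Compound 4 is therefore expected to give 3.5 nM, between 1.5 nM and 8 nM. The estimated step is a 1.0-fold higher number from compound 3 to compound 4 (0.01 log units; within the scatter), expected to stay within the scatter.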

Compound 4, inhibition constant: 5.4 nM
Compound 4: the middle estimate sits 1.5-fold (0.19 log units) below what was measured; measured number inside the range.
By their numbers in this assay, from the lowest: compounds 1, 3, 2 and 4 (each within the scatter of the next, the first and the last beyond it).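

In this assay, the step for chloro in place of iodo is a 1.6-fold higher number from compound 3 to compound 4 (0.20 log units; within the scatter) and the step for chloro in place of methoxy is a 1.4-fold higher number from compound 2 to compound 4 (0.13 log units; within the scatter), so iodo, methoxy and chloro read alike at this position, para to a large group. Going by these compounds alone, the one step beyond the scatter lies in another place on the same aryl ring: methyl in place of bromo gives a 2.2-fold higher number from compound 1 to compound 4 (0.33 log units; beyond the scatter). No measurement shown offers an explanation for these readings. From the compounds shown here alone, whether an amine or a carboxylic acid at the para position would also read alike remains open.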